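A few compounds are considered here, and "the series" means these few. Any claim that something is new, unique, unknown or untested is made for them only; others in the source may bear on it.

Measured compounds:
compound 1, `CC(C)c1ccc(OC(Cc2ccc3ccccc3c2)C(=O)O)cc1`, gives 50 mg/kg;
compound 2, `CCc1ccc(CC(C)(Oc2ccc(C(C)C)cc2)C(=O)O)cc1`, gives 0.1 mg/kg;
compound 3, `CCCc1ccc(CC(C)(Oc2ccc(C(C)C)cc2)C(=O)O)cc1`, gives 0.5 mg/kg.

All three were tested in a functional assay on the whole organism for inhibition, with Rattus norvegicus as the target; on this read-out higher numbers stand for an effect only at larger amounts of compound and lower numbers for an effect already at smaller amounts. Compound 1 stands highest of the three, well beyond the usual scatter from both compound 2 and compound 3. How the core of compound 1 differs from the core of compound 2 is not broken down here.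

Compound 2 and compound 3 differ in one place: methyl in place of hydrogen on a saturated chain carbon, two bonds along the chain from an aromatic carbon. This change gave a 5.0-fold higher number from compound 2 to compound 3 (0.70 log units; beyond the scatter).

The unmeasured compound 4, `CC(C)c1ccc(OC(C)(Cc2ccc3ccccc3c2)C(=O)O)cc1`, arises from compound 1 by a change of the same kind: methyl in place of hydrogen on a saturated chain carbon bound to a carbonyl carbon, an oxygen on an aromatic ring and a saturated chain carbon. The place is not the same, though. In compound 3 the methyl enters on a saturated chain carbon two bonds along the chain from an aromatic carbon, whereas in compound 4 it enters on a saturated chain carbon bound to a carbonyl carbon, an oxygen on an aromatic ring and a saturated chain carbon.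

Because compound 3 gave 0.5 mg/kg and compound 2 gave 0.1 mg/kg, both carrying a methyl at the place where compound 4 gains one, a lower number than compound 1 is expected for compound 4, while the earlier step from compound 2 to compound 3 went the other way. The expected step for compound 4 is therefore uncertain and set at a 5.0-fold lower number from compound 1 to compound 4 (0.70 log units; beyond the scatter). Compound 4 is estimated at 10 mg/kg, expected between 2 mg/kg and 60 mg/kg.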

Compound 4, dose for half-maximal effect: > 10 mg/kg
Compound 4 was reported as a limit; the forecaster's own chance of this, stated with the estimate: 5%; the middle value lies on the limit itself.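

In this assay compound 4 gives > 10 mg/kg, which is a limit of the assay and not a number. Among the compounds shown here, no step from compound 1 to compound 4 can therefore be read: the limit of > 10 mg/kg in this assay, at which 1 of the 4 values shown sits. The compounds shown leave open whether methyl in place of hydrogen at this place on the core of compound 1 raises or lowers the number in this assay, and by how much.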